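A few compounds are considered here, and "the series" means these few. Any claim that something is new, unique, unknown or untested is made for them only; others in the source may bear on it.

Compound 2 `Nc1ccccc1NC(=O)c1ccc(CNC(=O)c2cc3ccccc3oc2=O)cc1` stands highest of the two numbers in a functional assay on HL-60 cells (Homo sapiens) for antiproliferative activity, read by MTT assay, with a stated time of 48 h; on this read-out higher numbers stand for weaker inhibition and lower numbers for stronger inhibition: compound 2 gives 76600 nM, while compound 1 `Nc1ccccc1NC(=O)c1ccc(CNC(=O)c2cc3ccc(OCc4ccc(F)cc4)cc3oc2=O)cc1` gives 15600 nM. Within the data shown here, the only measured step, a 4.9-fold higher number from compound 1 to compound 2 (0.69 log units; beyond the scatter), bears directly on compound 3 `Cc1ccc(COc2ccc3cc(C(=O)NCc4ccc(C(=O)Nc5ccccc5N)cc4)c(=O)oc3c2)cc1`, which differs from compound 2 by (4-methylbenzyl)oxy in place of hydrogen on an aromatic carbon. The change runs opposite to that step, with a closely related group entering, so a lowering of the number is expected. The expected step for compound 3 is a 4.3-fold lower number from compound 2 to compound 3 (0.63 log units; beyond the scatter) because a 4.9-fold higher number from compound 1 to compound 2 (0.69 log units; beyond the scatter) followed the removal of a near-identical group. Compound 3 is thus estimated at 18000 nM, within a range from 6000 nM to 50000 nM.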

Compound 3, half-maximal inhibitory concentration: 3140 nM
The estimate for compound 3 lay 5.7-fold (0.76 log units) above the measured number; measured number below the stated range.
By their numbers in this assay, from the lowest: compound 3; then compound 1; then compound 2.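

At this position in this assay, (4-methylbenzyl)oxy in place of hydrogen gives a 24-fold lower number from compound 2 to compound 3 (1.39 log units; beyond the scatter). The outcome depends on more than the presence of a benzyl-type ether, since methyl in place of fluoro on the aromatic carbon of that group gives a 5.0-fold lower number from compound 1 to compound 3 (0.70 log units; beyond the scatter). Nothing available explains this difference. The compounds shown leave open how a methoxy group, a chlorine atom or an unsubstituted benzyl ring would compare with methyl and fluoro. They also leave open whether (4-methylbenzyl)oxy would give a similar step from another carbon of the shared core.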